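Iodo for chloro on the meta-substituted phenyl of compound 3

The compounds below may be only part of what the source reports. "The series", "measured", "known", "first", "only" and "open" are said of these compounds alone.

Compound 1 `O=C(N/N=C/C1=C(Cl)c2ccccc2CCC1)c1ccccc1` gives > 100000 nM in a functional assay on HeLa cells (Homo sapiens) for inhibition, read by sulforhodamine B assay, with a stated time of 48 h (a higher number here means a weaker inhibitor of growth, a lower number a stronger inhibitor of growth), a limit of that assay.
Compound 2 `Cc1ccc(C(=O)N/N=C/C2=C(Cl)c3cc(C)c(C)cc3CCC2)cc1` gives > 100000 nM in this assay, again a limit.
Compound 3 `Cc1cc2c(cc1C)C(Cl)=C(/C=N/NC(=O)c1cccc(Cl)c1)CCC2` gives 770 nM in this assay.

For the measured compounds named here, compound 3 thus holds the only number among the three; the other two sit at the limit of > 100000 nM in this assay, at which 2 of the 3 values shown sit. Compound 4 `Cc1cc2c(cc1C)C(Cl)=C(/C=N/NC(=O)c1cccc(I)c1)CCC2` differs from compound 3 by iodo in place of chloro on an aromatic carbon. Going by the values given here, the single measured step, an at least 120-fold lower number from compound 2 to compound 3 (2.11 log units; beyond the scatter), also changes the ring on the carbonyl carbon, but swaps 4-methylphenyl for 3-chlorophenyl and is large; it says nothing about one halogen against another. Among the compounds with values here, no measured step bears on exchanging chloro for iodo, so no step beyond the scatter is expected in this assay. Compound 4 is expected to give 700 nM, within 250 nM to 2500 nM. The expected step is a 1.1-fold lower number from compound 3 to compound 4 (0.04 log units; within the scatter).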

Compound 4, concentration for 50% growth inhibition: > 100000 nM
Compound 4 ended at the assay's limit (the forecaster's own chance of this, stated with the estimate: 10%); at least 140-fold (2.15 log units) between middle value and limit.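

In this assay, exchanging only the halogen, 3-chlorophenyl to 3-iodophenyl, gives an at least 120-fold higher number from compound 3 to compound 4 (2.11 log units; beyond the scatter), so this one place decides the outcome even when the rest of compound 3 stays untouched and the ring itself is kept. Compound 1, compound 2 and compound 4 share one limit of the assay: the limit of > 100000 nM in this assay, at which 3 of the 4 values shown sit. The step from compound 2 to compound 4 cannot be read, since both values are limits.

On these data alone, whether chloro is unique here stays open, as bromo and fluoro do not appear at this place. Nor do a nitrile, a methoxy group or an amine.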